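Three Amides at the Limit and a Fourth to Come

A few compounds are considered here, and "the series" means these few. Any claim that something is new, unique, unknown or untested is made for them only; others in the source may bear on it.

Compound 1 `COc1ccc2c(=O)c(/C=C/C(=O)Nc3cccc(Cl)c3)coc2c1` was tested in a functional assay on L02 cells (Homo sapiens) for inhibition, read by MTT assay, with a stated time of 48 h; on this read-out higher numbers stand for weaker inhibition and lower numbers for stronger inhibition. In this assay compound 1 gives > 200000 nM, which is a limit of the assay and not a number. Compound 2 `COc1ccc2c(=O)c(/C=C/C(=O)Nc3ccc(Cl)cc3)coc2c1` carries a 4-chlorophenyl in place of the 3-chlorophenyl on an amide-type nitrogen. In this assay compound 2 gives > 200000 nM, again a limit. The step that the two limits leave unreadable from compound 1 to compound 2 is therefore unreadable. For the measured compounds named here, compound 3 `Cc1ccccc1NC(=O)/C=C/c1coc2cc(O)ccc2c1=O` differs from compound 1 in more than one place, so no single step connects them. In this assay compound 3 gives > 200000 nM, once more a limit. All three values sit at the limit of > 200000 nM in this assay, at which 3 of the 3 values shown sit.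

Compound 4 `COc1ccc2c(=O)c(/C=C/C(=O)NCc3ccc(F)cc3)coc2c1` has not been measured. It differs from compound 1 as follows: 4-fluorobenzyl in place of 3-chlorophenyl on an amide-type nitrogen. Going by the values given here, no measured step reads on this change, and the one computed step is unreadable, so the data give no size for any change in this assay. Compound 4 is therefore expected to give 200000 nM, with a range from 50000 nM to 400000 nM, most probably again as a limit. The expected step of a number no higher from compound 1 to compound 4 (the limit leaves the size open) is accordingly estimated as none beyond the scatter.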

Compound 4, half-maximal inhibitory concentration: > 200000 nM
Compound 4: a limit, no number; the forecaster's own chance of this, stated with the estimate: 80%; the middle value sits exactly at the limit.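

In this assay compound 4 gives > 200000 nM, which is a limit and not a number. The steps from compound 1 and from compound 2 to compound 4 therefore cannot be read. The compounds shown leave open how strongly any of them inhibits, and whether the group on the amide-type nitrogen matters: the limit of > 200000 nM in this assay, at which 4 of the 4 values shown sit.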